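This account rests on a few compounds, and the source may have more. Where it says the series, first, only, none or still open, it means among the compounds named here.

Working notes on the oxazolidinone series, solubility leg.

Three members of the series have a number in a physicochemical assay for solubility, read by HPLC, with a stated time of 24 h; on this read-out higher numbers stand for higher solubility and lower numbers for lower solubility. Compound 1 `O=C1O[C@@H](CO)CN1c1ccc(-n2cc(-c3ccccn3)cn2)c(F)c1` gives 56400 nM in this assay and stands highest of the three measured numbers. Compound 2 `O=C1O[C@@H](Cn2ccnc2)CN1c1ccc(-n2cc(-c3ccccn3)cn2)c(F)c1` gives 12300 nM, and compound 3 `O=C1O[C@@H](CSc2cccs2)CN1c1ccc(-n2cc(-c3ccccn3)cn2)c(F)c1` gives 8500 nM. Both steps away from compound 1 run in the same direction: a 4.6-fold lower number from compound 1 to compound 2 (0.66 log units; beyond the scatter), and a 6.6-fold lower number from compound 1 to compound 3 (0.82 log units; beyond the scatter). The two replacements themselves sit close together, since a 1.4-fold lower number from compound 2 to compound 3 (0.16 log units; within the scatter).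

The next member to be measured is compound 4 `CS(=O)(=O)NC[C@H]1CN(c2ccc(-n3cc(-c4ccccn4)cn3)c(F)c2)C(=O)O1`. Relative to compound 1 the change is methanesulfonamido in place of hydroxy on a saturated chain carbon bound to a saturated ring carbon. The two measured steps from compound 1 bear on this one: each of them swapped the hydroxy on a saturated chain carbon bound to a saturated ring carbon for a larger group and each lowered the number by a modest amount beyond the scatter. The entering methanesulfonamido is also larger than hydroxy, but unlike the imidazolyl or thiophenylsulfanyl groups it keeps a hydrogen-bond donor and adds two acceptors, so the drop is expected to be smaller than those already seen, and may not clear the scatter.

The expectation for compound 4 in this assay is therefore a step of a 2.0-fold lower number from compound 1 to compound 4 (0.30 log units; within the scatter) from compound 1, placing compound 4 at an estimated 28000 nM, within a range from 9000 nM to 75000 nM.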

Compound 4, solubility: 2300 nM
Compound 4: the middle estimate sits 12-fold (1.09 log units) above what was measured; measured number outside the range, below it.
By their numbers in this assay, from the lowest: compound 4; then compounds 3 and 2 (each within the scatter of the next); then compound 1.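

In this assay, among these compounds, the methanesulfonamido group on a saturated chain carbon bound to a saturated ring carbon gives the first large step at this position: a 25-fold lower number from compound 1 to compound 4 (1.39 log units; beyond the scatter). The two earlier replacements stood within the scatter of each other, so they could have been read as a single lower level for anything larger than hydroxy, but methanesulfonamido falls clear of both, with a 5.3-fold lower number from compound 2 to compound 4 (0.73 log units; beyond the scatter) and a 3.7-fold lower number from compound 3 to compound 4 (0.57 log units; beyond the scatter). Compound 4 is now the lowest of the four compounds, although the entering group carries 1 hydrogen-bond donor, the same count as the hydroxy it replaces, so among these compounds that count does not track the number.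

Nothing shown here accounts for the size of these steps.

The compounds shown leave open whether the low number in compound 4 goes with the sulfonyl part of the group or with the chain nitrogen, a question that an acetamido or a plain amino group on the same carbon would help to separate. They also leave open how a carboxylic acid at this position would read in this assay against compound 1.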